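A few compounds are considered here, and "the series" means these few. Any claim that something is new, unique, unknown or untested is made for them only; others in the source may bear on it.

In an ADME assay for permeability, using PAMPA, with a stated time of 4 h, at pH 7.4 (a higher number here means that the compound crosses the layer faster, a lower number that the compound crosses the layer more slowly), two compounds have been measured so far. Compound 2 `CN(C[C@H]1Cc2ncccc2CN1)[C@H]1CCCc2cccnc21` gives 1300 nm/s, the higher of the two numbers, and the gap down to compound 1 `NCCCCN(C[C@H]1Cc2cccnc2CN1)[C@H]1CCCc2cccnc21`, at 6 nm/s, lies beyond the scatter. These two compounds differ in more than one place, so their gap cannot be read as the result of a single change. Still unmeasured is compound 3 `NC(=O)NCCCCN(C[C@H]1Cc2ncccc2CN1)[C@H]1CCCc2cccnc21`, which keeps the core of compound 2 and differs from it in one place: 3-ureidopropyl in place of hydrogen on a saturated chain carbon bound to an amine nitrogen. Going by the values given here, no step between measured compounds shows what such a change does in this assay. Among the compounds with values here, the only guide is compound 1 at 6 nm/s, which also carries a chain on that amine nitrogen, though on a core that is not identical. A drop beyond the scatter is therefore expected, an estimated 33-fold lower number from compound 2 to compound 3 (1.51 log units; beyond the scatter). For compound 3 the expected value is 40 nm/s, with an estimated range of 8 nm/s to 200 nm/s.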

Compound 3, apparent permeability: 2 nm/s
Estimate against measurement, compound 3: 20-fold (1.30 log units) above, outside the stated range (below it).
By their numbers in this assay, from the lowest: compound 3; then compound 1; then compound 2.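

In this assay there is now a single change to read at this position: 3-ureidopropyl in place of hydrogen on a saturated chain carbon bound to an amine nitrogen goes with a 650-fold lower number from compound 2 to compound 3 (2.81 log units; beyond the scatter). The only earlier gap lay between compounds that differ in more than one place, so it could not show what a change at this position alone does; this step shows that, on the core of compound 2, this chain lowers the number by a large margin, well beyond the scatter. Nothing measured here gives a reason for the size of this step, which therefore stands as an observation only.

It remains open whether the step follows the ureido end or the chain that carries it: a plain propyl chain, the same chain ending in an amine or a carboxylic acid, and a shorter or longer chain bearing the ureido group are all absent from the compounds shown. As far as these compounds go, whether the change would weigh the same on the core of compound 1 also stays open, as compound 1 has no partner here that differs from it in one place.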